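The source may report more compounds than this note shows. Statements on the series, on what has been measured and on what is new or still open speak of the compounds shown alone.

- Compound 1 `CCOC(=O)C(C)Oc1cc(O)c2c(=O)c(O)c(-c3ccc(OC)cc3)oc2c1CC=C(C)C`: 2500 nM
- Compound 2 `COc1ccc(-c2oc3c(CC=C(C)C)c(OCCCOC(=O)CCCC(=O)O)cc(O)c3c(=O)c2OCCCOC(=O)CCCC(=O)O)cc1`: 8100 nM
- Compound 3 `CCOC(=O)C(Oc1cc(O)c2c(=O)c(OC(C(=O)OCC)C(=O)OCC)c(-c3ccc(OC)cc3)oc2c1CC=C(C)C)C(=O)OCC`: 85000 nM

In a functional assay on MDA-MB-435S cells (Homo sapiens) for cytotoxicity, read by MTT assay (a higher number here means a weaker inhibitor, a lower number a stronger inhibitor), compound 1 has the lowest number of the three, and both gaps to the others lie beyond the usual scatter. Compound 4 `COc1ccc(-c2oc3c(CC=C(C)C)c(OCC(=O)O)cc(O)c3c(=O)c2O)cc1` is still unmeasured. It carries carboxymethyl in place of 1-(ethoxycarbonyl)ethyl on an oxygen on an aromatic ring. For the measured compounds named here, no measured pair isolates this change, so the direction is a judgement. Compound 2 also ends in free carboxyl groups and gives 8100 nM, which points towards a higher number, though compound 3 has no such ends and gives 85000 nM. The expected change is a 4.8-fold higher number from compound 1 to compound 4 (0.68 log units; beyond the scatter), probably beyond the scatter. The estimated value for compound 4 is 12000 nM, with an expected range of 4000 nM to 40000 nM.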

Compound 4, half-maximal inhibitory concentration: 13500 nM
Beside the measured number, compound 4's estimate is 1.1-fold (0.05 log units) below it; low and high end bracket the measured number.
By their numbers in this assay, from the lowest: compound 1; then compounds 2 and 4 (each within the scatter of the next); then compound 3.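

In this assay, for the compounds shown here, putting carboxymethyl in place of 1-(ethoxycarbonyl)ethyl on this oxygen gives a 5.4-fold higher number from compound 1 to compound 4 (0.73 log units; beyond the scatter) and isolates a single change at this position for the first time. The group carried on this oxygen therefore matters for this read-out, and here the carboxymethyl compound is the weaker one. Nothing measured here explains the step.

The change replaces the ethyl ester with a free carboxylic acid and also removes a methyl branch, so the two cannot be told apart. An ethoxycarbonylmethyl group or a 1-carboxyethyl group on the same oxygen would separate them.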